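Truncating the aryl ether of compound 1

A few compounds are considered here, and "the series" means these few. Any claim that something is new, unique, unknown or untested is made for them only; others in the source may bear on it.

Compound 1 `CCCNc1cc(Oc2ccc(NC(=O)Nc3cccc(C(F)(F)F)c3)cc2)ncn1` gives 32 nM in an assay on isolated protein for inhibition of serine/threonine-protein kinase TNNI3K (Homo sapiens); on this read-out higher numbers stand for weaker inhibition and lower numbers for stronger inhibition. It stands level with compound 3 `C[C@H](O)CNc1cc(Oc2ccc(NC(=O)Nc3cccc(C(F)(F)F)c3)cc2)ncn1`, which gives 32 nM, and together they hold the lowest numbers of the three measured; compound 2 `CC(C)CNc1cc(Oc2ccc(NC(=O)Nc3cccc(C(F)(F)F)c3)cc2)ncn1` gives 50 nM. Every measured step alters only the chain on the ring nitrogen: a 1.6-fold higher number from compound 1 to compound 2 (0.19 log units; within the scatter), no change at the digits printed from compound 1 to compound 3 (within the scatter), a 1.6-fold lower number from compound 2 to compound 3 (0.19 log units; within the scatter), each within the scatter. Compound 4 `O=C(Nc1ccc(Oc2ccncc2)cc1)Nc1cccc(C(F)(F)F)c1` carries a different change: pyridin-4-yl in place of 6-(propylamino)pyrimidin-4-yl on an oxygen on an aromatic ring. Among the measured compounds shown here, no measured step removes the chain or changes the ring itself, so the steps seen show only that small edits to the chain stay within scatter and do not bear on this removal. A step toward a higher number is therefore expected, with wide uncertainty: for compound 4 the estimate is 300 nM (range 60 nM to 3000 nM), meaning a 9.4-fold higher number from compound 1 to compound 4 (0.97 log units; beyond the scatter).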

Compound 4, half-maximal inhibitory concentration: 50 nM
For compound 4 the middle estimate is 6.0-fold (0.78 log units) above the measured one; the measured number lies below the stated range.
By their numbers in this assay, from the lowest: compounds 1, 3, 2 and 4 (each within the scatter of the next).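

In this assay, pyridin-4-yl in place of 6-(propylamino)pyrimidin-4-yl gives a 1.6-fold higher number from compound 1 to compound 4 (0.19 log units; within the scatter). The earlier steps shown here only edited the chain, whereas this one removes the chain and alters the ring, and even so the number stays within the scatter, so in these four compounds the propylamino group is not required for a value at this level. No supporting measurement is available to explain this.

The chain and ring changes remain unseparated; pyrimidin-4-yl without a chain would part them. From the compounds shown here alone, whether a carboxylic acid or an amine on pyridin-4-yl keeps this level also remains open.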